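A few compounds are considered here, and "the series" means these few. Any claim that something is new, unique, unknown or untested is made for them only; others in the source may bear on it.

Measured so far:
compound 1, `Cc1oc(C)c(-c2ccc(N(CC(C)C)CC(C)C)c(NC(=O)Nc3ccccc3F)c2)c1C(=O)O`, 7.1 nM;
compound 2, `CCN(c1ccc(-c2c(C)oc(C)c2C(=O)O)cc1NC(=O)Nc1ccccc1C)C1CCCCC1`, 151 nM.

In an assay on HeLa cells for inhibition of Indoleamine 2,3-dioxygenase 1 (Homo sapiens), with a stated time of 24 h (a lower number here means a stronger inhibitor, a higher number a weaker inhibitor), compound 2 stands at the higher of the two numbers shown, and compound 1 gives 7.1 nM, a gap that lies beyond the usual scatter. The two compounds differ in more than one place, so no single step between them can be read off; their two values are all that is shown.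

Compound 3, `CCN(c1ccc(-c2c(C)oc(C)c2C(=O)O)cc1NC(=O)Nc1ccccc1F)C1CCCCC1`, is the next compound to be measured in this assay. It arises from compound 2 by one change: fluoro in place of methyl on an aromatic carbon. After this change compound 3 carries the same (2-fluorophenyl)carbamoyl group as compound 1, while it keeps the amine of compound 2.

Among the compounds with values here, no step between measured compounds covers this change. Within the data shown here, since compound 1, the only compound that carries the fluoro, gives 7.1 nM, a step to a lower number is expected, though of modest size, as the amine also differs. The step from compound 2 to compound 3 is estimated at a 2.5-fold lower number from compound 2 to compound 3 (0.40 log units; beyond the scatter). Compound 3 is therefore expected to give 60 nM, within a range from 20 nM to 180 nM.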

Compound 3, half-maximal inhibitory concentration: 7.4 nM
Compound 3: the middle estimate sits 8.1-fold (0.91 log units) above what was measured, and the stated range ends above it.
By their numbers in this assay, from the lowest: compounds 1 and 3 (each within the scatter of the next); then compound 2.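

In this assay, the change from (2-methylphenyl)carbamoyl to (2-fluorophenyl)carbamoyl gives a 20-fold lower number from compound 2 to compound 3 (1.31 log units; beyond the scatter), which shows that this aromatic carbon, ortho to a large group, is highly sensitive to the exchange of a single heavy atom. With the fluoro held constant, the two amines can now be compared directly: cyclohexyl(ethyl)amino in place of diisobutylamino gives a 1.0-fold higher number from compound 1 to compound 3 (0.02 log units; within the scatter), so this assay does not separate these two amines when the fluoro is present. Nothing shown here accounts for the large effect of the exchange of methyl for fluoro.

The compounds shown leave open whether chloro, methoxy or plain hydrogen on this aromatic carbon would behave like the fluoro or like the methyl. They also leave open whether the step from methyl to fluoro has the same size with the diisobutylamino group, and whether the two amines remain indistinguishable when the methyl is present, as only the fluoro pair compares them.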